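The source may hold more compounds than are shown below. What is called first, only, known or untested is meant among the compounds shown, and "the series" means these compounds.

In a functional assay on CHO cells for antagonist activity at prostaglandin E2 receptor EP3 subtype (Homo sapiens), read by cAMP accumulation, with a stated time of 30 min (a lower number here means a stronger inhibitor, a higher number a weaker inhibitor), compound 1 `C/C(=C1/OC(=O)NC1=O)C(c1ccc(-c2ccc3cccc(F)c3c2)[nH]c1=O)C(C)C` gives 39 nM and compound 2 `CC(C)C(c1ccc(-c2ccc3cccc(F)c3c2)[nH]c1=O)C1SC(=O)NC1=O` gives 110 nM. Among the compounds with values here, compound 2 therefore stands with the highest of the two numbers in this assay, its only neighbour being compound 1, with a 2.8-fold higher number from compound 1 to compound 2 (0.45 log units; beyond the scatter) separating them. Compound 3 `CC(C)C(/C=C1\NC(=O)NC1=O)c1ccc(-c2ccc3cccc(F)c3c2)[nH]c1=O` has not yet been measured. It differs from compound 2 in one place: a group of 8 heavy atoms (4 carbon, 2 nitrogen, 2 oxygen; one five-membered non-aromatic ring with 2 hetero atoms) in place of a group of 7 heavy atoms (3 carbon, 1 nitrogen, 2 oxygen, 1 sulfur; one five-membered non-aromatic ring with 2 hetero atoms), on a saturated chain carbon bound to an aromatic carbon and a saturated chain carbon. Within the data shown here, the sole measured step that bears on this change is a 2.8-fold higher number from compound 1 to compound 2 (0.45 log units; beyond the scatter), a modest rise produced by exchanging the ring group at the same carbon. A swap of comparable size is expected here, and because compound 1, whose group likewise carries a double bond outside the aromatic rings, gave 39 nM, the step is expected to run downward, a 2.2-fold lower number from compound 2 to compound 3 (0.34 log units; beyond the scatter). Compound 3 is thus estimated at 50 nM, with a range from 18 nM to 150 nM.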

Compound 3, half-maximal inhibitory concentration in the prostaglandin E2 receptor EP3 subtype assay: 87 nM
Compound 3: middle estimate off by 1.7-fold (0.24 log units), on the low side; low and high end bracket the measured number.
By their numbers in the prostaglandin E2 receptor EP3 subtype assay, from the lowest: compound 1; then compounds 3 and 2 (each within the scatter of the next).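

In the prostaglandin E2 receptor EP3 subtype assay, the step of a 1.3-fold lower number from compound 2 to compound 3 (0.10 log units; within the scatter) shows that the 2,4-dioxo-1,3-thiazolidin-5-yl group can be exchanged for the entering ring group, with its extra double bond outside the aromatic rings, without a change beyond the scatter. The other step, a 2.2-fold higher number from compound 1 to compound 3 (0.35 log units; beyond the scatter), leaves compound 1 with the lowest number of the three, so that extra double bond does not by itself bring compound 3 to the level of compound 1. In a physicochemical assay for solubility, measured as kinetic solubility, at pH 2 (a lower number here means a less soluble compound, a higher number a more soluble compound), compound 2 gives 11300 nM and compound 3 gives 7500 nM, and a 1.5-fold lower number from compound 2 to compound 3 (0.18 log units; within the scatter) also stays within the scatter.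

Nothing available accounts for what sets compound 1 apart from compound 3. On these data alone, whether an amine or a carboxylic acid in place of the ring group, on this saturated chain carbon bound to an aromatic carbon and a saturated chain carbon, would hold the number in the prostaglandin E2 receptor EP3 subtype assay remains open.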